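The source may hold more compounds than are shown below. What is called first, only, known or untested is meant among the compounds shown, and "the series" means these compounds.

Measured so far in an ADME assay on RAW264.7 cells (Mus musculus) for cytotoxicity, read by MTT assay, with a stated time of 18 h; a higher number here means that more compound is tolerated, a lower number that less compound is tolerated:
- compound 1, `C=C1C(=O)OC[C@H]1CCOC(=O)Nc1ccc(C(C)C)cc1`, gives 12400 nM
- compound 2, `C=C1C(=O)OC[C@@H]1CCOC(=O)Nc1ccc(I)cc1`, gives 12500 nM
- compound 3, `C=C1C(=O)OC[C@@H]1CCOC(=O)Nc1c(C)cccc1C(C)C`, gives only a limit, > 50000 nM

Compound 1 carries an isopropyl group on its aromatic ring and, in this assay, gives 12400 nM, the lower of the two numbers shown. Compound 2 sits at 12500 nM, and the two values fall within the usual scatter of each other, so no order between them can be claimed. For compound 3 only a limit was reported, > 50000 nM, which is the limit of > 50000 nM in this assay, at which 1 of the 3 values shown sits, and not a number. Among the measured compounds shown here, no pair of measured compounds here differs in just one place, so no measured step is available to lean on.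

Compound 4, `C=C1C(=O)OC[C@H]1CCOC(=O)Nc1ccc(CCCC)cc1`, has not yet been measured in this assay. It differs from compound 1 by butyl in place of isopropyl on an aromatic carbon. For the measured compounds named here, with no measured step of this kind to compare against, a small change is expected, in either direction, of a size that stays within the scatter: the estimated step of a 1.2-fold lower number from compound 1 to compound 4 (0.09 log units; within the scatter). Compound 4 is therefore expected to give about 10000 nM, most likely between 4000 nM and 30000 nM.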

Compound 4, half-maximal cytotoxic concentration: 15900 nM
Compound 4: the middle estimate sits 1.6-fold (0.20 log units) below what was measured, within the range that was stated.
By their numbers in this assay, from the lowest: compounds 1, 2 and 4 (each within the scatter of the next). At a limit, above all of these: compound 3.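

Putting butyl in place of isopropyl on an aromatic carbon gives a 1.3-fold higher number from compound 1 to compound 4 (0.11 log units; within the scatter) in this assay. Among the compounds shown here, this is the first measured step between two compounds that differ in one place, and it shows that this assay does not tell these two alkyl groups apart at this position, so the amount of compound tolerated holds steady across the swap. The information available here offers no measured explanation for this result.

As far as these compounds go, one swap between two hydrocarbon groups says little about the position as a whole, so it remains open whether the same holds for a longer chain, or for a group of a different kind such as an amine or a carboxylic acid. From the compounds shown here alone, it is also open whether this insensitivity would carry over to other places on the ring.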